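A few compounds are considered here, and "the series" means these few. Any claim that something is new, unique, unknown or untested is made for them only; others in the source may bear on it.

Working notes on the series.

Compound 1 `CN(C)C(=O)c1cc2cnc(Nc3ccc(S(=O)(=O)NCCCCN=C=S)cc3)nc2n1C1CCCC1` and compound 2 `CN(C)C(=O)c1cc2cnc(Nc3ccc(S(=O)(=O)NCCCCCN=C=S)cc3)nc2n1C1CCCC1` share a core and carry an isothiocyanate-terminated chain on a sulfonamide nitrogen. In a functional assay on A549 cells (Homo sapiens) for inhibition, read by CCK-8 assay, with a stated time of 72 h, tested at 10 uM (on this read-out higher numbers stand for a stronger effect at the one concentration tested and lower numbers for a weaker effect), compound 1 gives 101%. In this assay compound 2 gives 102%. Within the data shown here, the single change between them, (a group of 4 heavy atoms (2 carbon, 1 nitrogen, 1 sulfur; no ring) in place of a group of 3 heavy atoms (1 carbon, 1 nitrogen, 1 sulfur; no ring), on a saturated chain carbon, four bonds along the chain from a sulfonamide nitrogen), produced a number 1 percentage points higher from compound 1 to compound 2 (within the scatter).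

Compound 3 `CN(C)C(=O)c1cc2cnc(Nc3ccc(C(=O)NCCCN=C=S)cc3F)nc2n1C1CCCC1` carries its chain on an amide-type nitrogen instead and has a fluorine on the aryl ring. In this assay compound 3 gives 60.2%, the lowest of the three numbers; the gaps to compound 1 and to compound 2 are both beyond the scatter. The difference between the core of compound 3 and the core of compound 1 is not broken down here.

Compound 4 `CN(C)C(=O)c1cc2cnc(Nc3ccc(C(=O)NCCCCN=C=S)cc3F)nc2n1C1CCCC1` is not yet measured. It differs from compound 3 by a group of 4 heavy atoms (2 carbon, 1 nitrogen, 1 sulfur; no ring) in place of a group of 3 heavy atoms (1 carbon, 1 nitrogen, 1 sulfur; no ring), on a saturated chain carbon, three bonds along the chain from an amide-type nitrogen. Among the measured compounds shown here, this is the same kind of change as the one from compound 1 to compound 2, but not the same: there the place was a saturated chain carbon four bonds along the chain from a sulfonamide nitrogen, here it is a saturated chain carbon three bonds along the chain from an amide-type nitrogen, and the reference pair sits near complete inhibition where a step has little room to show.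

For compound 4 the expected step is a number 3.8 percentage points higher from compound 3 to compound 4 (within the scatter), set small because a number 1 percentage points higher from compound 1 to compound 2 (within the scatter) lay within the scatter; compound 3 at 60.2% leaves more room, so the range is kept wide.

Compound 4 is expected to give 64% in this assay, estimated between 45% and 84%.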

Compound 4, a percentage reported as inhibition, at one concentration (the size of the read-out at that concentration, not a potency): 24.4%
Estimate against measurement, compound 4: 39.6 percentage points above; the measured number lies below the stated range.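

Adding one carbon to the isothiocyanate-terminated chain does not carry over as a fixed step between the two cores in this assay. On the core of compound 3 it gives a number 35.8 percentage points lower from compound 3 to compound 4 (beyond the scatter), against a number 1 percentage points higher from compound 1 to compound 2 (within the scatter) on the core of compound 1, and the two steps differ: the same change on two cores in this assay, a number 1 percentage points higher (within the scatter) from compound 1 to compound 2 and a number 35.8 percentage points lower (beyond the scatter) from compound 3 to compound 4, 36.8 percentage points apart, beyond the scatter of two such steps

This shows that the flat step on the sulfonamide pair is no guide to the amide-type pair, but it does not show which difference between the cores accounts for the gap, since the nitrogen carrying the chain, the fluorine and the chain lengths all differ between the two pairs. Compound 1 gives 101% and compound 2 gives 102%, so the data cannot tell whether that flat step is small in its own right or only lacks room on this read-out, and each core offers a single pair measured at one concentration.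

Open, on these data alone, is whether a longer chain on the core of compound 4 lowers the number further, and whether the drop persists on a matching pair without the fluorine. Also open, as far as these compounds go, is how an amine or a carboxylic acid at the chain end, in place of the isothiocyanate, would read on either core.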